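Ester to acid at the amide tail of a chromone kinase inhibitor

The compounds below may be only part of what the source reports. "The series", "measured", "known", "first", "only" and "open" are said of these compounds alone.

Compound 1 `CCCC(=O)Nc1cccc(NC(=O)COc2ccc3c(=O)ccoc3c2)c1`: 1430 nM
Compound 2 `COC(=O)c1ccc(C(=O)Nc2cccc(NC(=O)COc3ccc4c(=O)ccoc4c3)c2)cc1`: 72 nM

In an assay on isolated protein for inhibition of Rho-associated protein kinase 1 (Homo sapiens), read by scintillation counting, radiometric assay and 33P incorporation, with a stated time of 40 min, in the presence of a further agent that is not named here (a higher number here means a weaker inhibitor, a lower number a stronger inhibitor), compound 2 gives the lowest number of the two measured compounds; the step of a 20-fold lower number from compound 1 to compound 2 (1.30 log units; beyond the scatter) set it apart from compound 1. Compound 3 `O=C(COc1ccc2c(=O)ccoc2c1)Nc1cccc(NC(=O)c2ccc(C(=O)O)cc2)c1` is not yet measured. It differs from compound 2 by hydrogen in place of methyl on an oxygen next to a carbonyl group. Within the data shown here, no measured step touches this place, so the only guide is the value of compound 2 itself. The step of a 1.7-fold higher number from compound 2 to compound 3 (0.22 log units; within the scatter) is expected to stay within the scatter. Compound 3 is therefore estimated at 120 nM, with a range from 30 nM to 600 nM.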

Compound 3, half-maximal inhibitory concentration: 6890 nM
Beside the measured number, compound 3's estimate is 57-fold (1.76 log units) below it; measured number above the stated range.
By their numbers in this assay, from the lowest: compound 2; then compound 1; then compound 3.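

Methoxycarbonyl and carboxy proved far from interchangeable at this position: in this assay there is a 96-fold higher number from compound 2 to compound 3 (1.98 log units; beyond the scatter) although only one methyl leaves. The gain that 4-(methoxycarbonyl)phenyl brought over propyl does not survive in 4-carboxyphenyl, which instead shows a 4.8-fold higher number from compound 1 to compound 3 (0.68 log units; beyond the scatter). Nothing available here accounts for this loss.

The compounds shown leave open whether the methyl itself matters, which an ethyl ester could test. They also leave open whether a primary amide or a hydroxymethyl group at this place would keep the value of compound 2 or fall towards that of compound 3.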